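The source may report more compounds than this note shows. Statements on the series, on what has been measured and on what is new or still open speak of the compounds shown alone.

Compound 1 `O=C(Nc1cccc(I)c1)C(Cl)Cl` carries iodo on an aromatic carbon, and in a functional assay on KB cells (Homo sapiens) for antiproliferative activity, read by MTT assay, with a stated time of 72 h (on this read-out lower numbers stand for stronger inhibition and higher numbers for weaker inhibition), compound 1 gives 5250 nM. Compound 2 `COc1cccc(NC(=O)C(Cl)Cl)c1` gives 57700 nM in this assay. The change between these two, (methoxy in place of iodo on an aromatic carbon), produced an 11-fold higher number from compound 1 to compound 2 (1.04 log units; beyond the scatter). Compound 3 `O=C(Nc1ccc(I)cc1)C(Cl)Cl` is built from the same atoms as compound 1 joined differently; the difference between the two cores is not broken down here. In this assay compound 3 gives 66200 nM, which lies within the scatter of the value of compound 2 and beyond the scatter from the value of compound 1.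

Compound 4 `COc1ccc(NC(=O)C(Cl)Cl)cc1` is not yet measured. It relates to compound 3 by methoxy in place of iodo on an aromatic carbon, the same kind of change as that from compound 1 to compound 2, but here the place is para to a group of 6 heavy atoms, whereas in the earlier pair it was meta to a group of 6 heavy atoms. Going by the values given here, that earlier step is the only measured guide for this change. As far as these compounds go, the step from compound 3 to compound 4 in this assay is expected to be a 1.7-fold higher number from compound 3 to compound 4 (0.22 log units; within the scatter), smaller than the earlier one, because an 11-fold higher number from compound 1 to compound 2 (1.04 log units; beyond the scatter) started from a far lower number than compound 3 shows with 66200 nM, and whether the position of methoxy matters is untested. Compound 4 is estimated at 110000 nM, with a range from 40000 nM to 350000 nM; a result reported only as a limit would not be surprising.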

Compound 4, half-maximal inhibitory concentration: 278000 nM
The estimate for compound 4 lay 2.5-fold (0.40 log units) below the measured number, within the range that was stated.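

In this assay, methoxy in place of iodo on an aromatic carbon, here para to a group of 6 heavy atoms, gives a 4.2-fold higher number from compound 3 to compound 4 (0.62 log units; beyond the scatter), so the number moves the same way as it did on the core of compound 1. Set beside the earlier step, the size of the change does not differ measurably between the two cores: the same change on two cores in this assay, an 11-fold higher number (1.04 log units; beyond the scatter) from compound 1 to compound 2 and a 4.2-fold higher number (0.62 log units; beyond the scatter) from compound 3 to compound 4, 2.6-fold (0.42 log units) apart, within the scatter of two such steps. Going by these compounds alone, this supports carrying the iodo-to-methoxy change from one core to the other, at least in direction, but it rests on only two pairs and shows neither that the step would hold on a further core nor why replacing iodo raises the number.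

The compounds shown leave open how other groups on the same aromatic carbon would behave, for instance an amine, a nitrile, a carboxylic acid or a longer alkoxy chain, and whether any of them would keep the number nearer to that of an iodo compound than methoxy does. They also leave open whether the step holds at any other place on the ring, and whether it survives a change elsewhere in the molecule, such as an amine in place of a chlorine atom on the side chain.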